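The source may report more compounds than this note shows. Statements on the series, on what has been measured and on what is new or still open speak of the compounds shown alone.

In a functional assay on SW-620 cells (Homo sapiens) for cytotoxicity, read by MTT assay, with a stated time of 48 h (on this read-out lower numbers stand for stronger inhibition and higher numbers for weaker inhibition), compound 3 `CCCCCCCCCCCCCCNC(=O)[C@@H](NC(=O)/C=C/c1ccccc1)[C@@H](C)O` gives 200000 nM. Among the compounds with values here, that figure is level with compound 2 `CCCCCCCCCCCCCCNC(=O)[C@@H](NC(=O)c1ccco1)[C@@H](C)O`, which gives 200000 nM, and together they stand as the highest pair among the three numbers known so far; the step of no change at the digits printed from compound 2 to compound 3 (within the scatter) shows no change beyond the scatter. Furthest away is compound 1 `CCCCCCCCCCCCNC(=O)[C@@H](NS(=O)(=O)c1ccc(C)cc1)[C@@H](C)O`, whose value of 25600 nM lies well below both. Compound 4 `CCCCCCCCCCCCCCNC(=O)[C@@H](NS(=O)(=O)c1ccc(C)cc1)[C@@H](C)O` arises from compound 3 through the change ((4-methylphenyl)sulfonyl in place of (2-phenylethenyl)carbonyl on an amine nitrogen). Within the data shown here, no measured step covers this exchange directly. What bears on it is the pair compound 1 and compound 4, which differ only in the length of the saturated chain on the amide and share the same (4-methylphenyl)sulfonyl group; compound 1 sits far below compound 3, while compound 2 and compound 3 show that two other carbonyl-linked groups on the longer chain both give the high figure. On that basis the step of a 5.7-fold lower number from compound 3 to compound 4 (0.76 log units; beyond the scatter) is expected to run downward, towards the region of compound 1. The value of compound 4 is therefore estimated at 35000 nM, within 12000 nM to 120000 nM.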

Compound 4, half-maximal inhibitory concentration: 15200 nM
The estimate for compound 4 lay 2.3-fold (0.36 log units) above the measured number; low and high end bracket the measured number.
By their numbers in this assay, from the lowest: compounds 4 and 1 (each within the scatter of the next); then compounds 2 and 3 (each within the scatter of the next).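

The change on the amine nitrogen is what moves the number in this assay: (4-methylphenyl)sulfonyl in place of (2-phenylethenyl)carbonyl gives a 13-fold lower number from compound 3 to compound 4 (1.12 log units; beyond the scatter), and in place of (furan-2-yl)carbonyl it gives a 13-fold lower number from compound 2 to compound 4 (1.12 log units; beyond the scatter). On the same chain, then, the two carbonyl-linked groups share the high figure, while the sulfonyl group brings the number down by a large step. Keeping the sulfonyl group and placing ethyl in place of hydrogen on the saturated chain gives a 1.7-fold lower number from compound 1 to compound 4 (0.23 log units; within the scatter), so the low number seen earlier holds on both chain lengths.

No measurement here explains why the sulfonyl group differs from the carbonyl-linked groups. On these data alone, whether a methanesulfonyl group, a chlorine on the aromatic ring or a still longer chain would keep the number this low remains open.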